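The source may report more compounds than this note shows. Statements on the series, on what has been measured and on what is new or still open speak of the compounds shown alone.

Compound 2, `COc1cc(OC)c2c(=O)cc(-c3ccc(OCCCN(C)C)cc3)oc2c1`, and compound 1, `COc1cc(OC)c2c(=O)cc(-c3ccc(OC4CCN(C)CC4)cc3)oc2c1`, share one core and differ only in the group on the oxygen on the aromatic ring. In a functional assay (Homo sapiens) for antiproliferative activity, read by resazurin assay, with a stated time of 48 h, tested at 10 uM (a lower number here means a weaker effect, a higher number a stronger effect of the compound at the concentration tested), compound 2 gives 59%, and compound 1 gives 49%; the two numbers lie within the scatter of each other, so neither can be set above the other. Within the data shown here, the only measured step here, a number 10 percentage points higher from compound 1 to compound 2 (within the scatter), replaced a ring with a chain and changed nothing beyond the scatter. Compound 3, `COc1cc(OC)c2c(=O)cc(-c3ccc(OC4CCNCC4)cc3)oc2c1`, is not yet measured. Among the measured compounds shown here, it differs from compound 2 by piperidin-4-yl in place of 3-(dimethylamino)propyl on an oxygen on an aromatic ring, which brings back a six-membered ring much like the one in compound 1. Since that earlier step stayed within the scatter, the same is expected here: compound 3 is estimated to give 50% in this assay, between 35% and 65%, a step of a number 9 percentage points lower from compound 2 to compound 3 (within the scatter) that is expected to stay within the scatter.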

Compound 3, a percentage reported as inhibition, at one concentration (the size of the read-out at that concentration, not a potency): 21%
Estimate against measurement, compound 3: 29 percentage points above, outside the stated range (below it).
By their numbers in this assay, from the lowest: compound 3; then compounds 1 and 2 (each within the scatter of the next).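

Hydrogen in place of methyl on an amine nitrogen in a ring gives a number 28 percentage points lower from compound 1 to compound 3 (beyond the scatter) in this assay, so at this position a single methyl on the ring nitrogen separates two compounds, whereas the exchange of ring for chain in a number 10 percentage points higher from compound 1 to compound 2 (within the scatter) did not. The change to piperidin-4-yl from 3-(dimethylamino)propyl likewise gives a number 38 percentage points lower from compound 2 to compound 3 (beyond the scatter), and in both steps compound 3 is the one that carries the hydrogen-bond donor counted on the ring amine. No measurement is at hand that explains this loss.

The compounds shown leave open whether a larger group on the ring nitrogen, such as ethyl or acetyl, would hold the effect seen with methyl. They also leave open whether a chain ending in a primary amine, such as 3-aminopropyl, would follow compound 3 or compound 2.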